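Series notes on Vero cytotoxicity, compound 1 to compound 4

This account rests on a few compounds, and the source may have more. Where it says the series, first, only, none or still open, it means among the compounds named here.

compound 1, `CCCCCC(=O)Nc1cc2nc(C3CCCCC3)[nH]c2cc1N1CCCC1`: > 100 ug/mL
compound 2, `CCCCCC(=O)Nc1cc2nc(C3CCCCC3)[nH]c2cc1N(CC)CC`: "not determined" (no result reported)
compound 3, `CCCCCC(=O)Nc1cc2nc(C3CCCCC3)[nH]c2cc1N(C)C`: > 100 ug/mL

In an ADME assay on Vero cells (Chlorocebus sabaeus) for cytotoxicity, read by resazurin assay, with a stated time of 3 days (a higher number here means a weaker inhibitor, a lower number a stronger inhibitor), compound 1 gives only a limit, > 100 ug/mL. Compound 3 likewise reaches only a limit, > 100 ug/mL. For compound 2 the result is "not determined" (no result reported). Within the data shown here, the single step between measured compounds, a step that the two limits leave unreadable from compound 1 to compound 3, cannot be sized because the limit of > 100 ug/mL in this assay, at which 2 of the 3 values shown sit, covers both of its ends.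

Compound 4, `COCCOC(=O)Nc1cc2nc(C3CCCCC3)[nH]c2cc1N1CCCC1`, differs from compound 1 by 2-methoxyethoxy in place of pentyl on a carbonyl carbon. No readable measured step bears on this change, so the expectation rests on compound 1 standing at the limit > 100 ug/mL. Compound 4 is expected to give 100 ug/mL, in the range 50 ug/mL to 200 ug/mL. This estimate means a step of a number no higher from compound 1 to compound 4 (the limit leaves the size open), expected to stay within the usual scatter.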

Compound 4, half-maximal inhibitory concentration: > 100 ug/mL
Compound 4: only a limit was reported; the forecaster's own chance of this, stated with the estimate: 75%; the middle value sits exactly at the limit.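

No size can be read for the step from compound 1 to compound 4 in this assay, because both compounds stand at the same limit: the limit of > 100 ug/mL in this assay, at which 3 of the 4 values shown sit. The compounds shown leave open whether 2-methoxyethoxy in place of pentyl on a carbonyl carbon shifts cytotoxicity at all.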